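The source may report more compounds than this note shows. Statements on the series, on what has been measured and on what is new or still open speak of the compounds shown alone.

Compound 1 `Cc1cc(NC(=O)Nc2ccc(C(=O)O)cc2)c2ccccc2n1` is the reference point. In a physicochemical assay for solubility, at pH 7.4 (on this read-out lower numbers stand for lower solubility and higher numbers for higher solubility), compound 1 gives 9300 nM, the second highest of the three numbers at hand. Compound 2 `Cc1cc(NC(=O)Nc2ccc(C(=O)O)c(O)c2)c2ccccc2n1` differs from it by a hydroxy in place of hydrogen on an aromatic carbon and gives 26600 nM; the step of a 2.9-fold higher number from compound 1 to compound 2 (0.46 log units; beyond the scatter) is modest yet beyond the scatter. For the measured compounds named here, compound 3 `Cc1cc(NC(=O)Nc2cccc3nsnc23)c2ccccc2n1` carries no carboxy and gives 300 nM, far below compound 1; it differs in more than one place, so no single step links the two.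

Compound 4 `Cc1cc(NC(=O)Nc2ccc(OC(F)(F)F)cc2)c2ccccc2n1` arises from compound 1 by trifluoromethoxy in place of carboxy on an aromatic carbon. The carboxy that leaves counts one hydrogen-bond donor; the trifluoromethoxy that enters has none. Going by the values given here, no measured step matches this change. Among the compounds with values here, the one single step, from compound 1 to compound 2, added a donor and raised the number, while compound 3, without a carboxy, stands well under compound 1 in this assay. The step to compound 4 is therefore expected to be a clear drop, a 23-fold lower number from compound 1 to compound 4 (1.37 log units; beyond the scatter). Compound 4 is expected to give 400 nM, most likely between 100 nM and 2000 nM.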

Compound 4, solubility: 300 nM
Compound 4: the middle estimate sits 1.3-fold (0.12 log units) above what was measured; the measured number falls inside the stated range.
By their numbers in this assay, from the lowest: compounds 3 and 4 (each within the scatter of the next); then compound 1; then compound 2.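

At this position, para to a large group, the carboxy itself is replaced for the first time among these single steps: in this assay, the change gives a 31-fold lower number from compound 1 to compound 4 (1.49 log units; beyond the scatter), which is large. The other single step, a 2.9-fold higher number from compound 1 to compound 2 (0.46 log units; beyond the scatter), keeps the carboxy and is only modest, so on this read-out replacing the carboxy with trifluoromethoxy moves the number much further than adding a hydroxy. Nothing measured here explains the drop.

The swap removes a hydrogen-bond donor and changes the group's size at once, so this single step cannot separate those two differences. As far as these compounds go, how a methyl ester, a primary amide or an amine at the same position would compare with the carboxy and the trifluoromethoxy remains open.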